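A few compounds are considered here, and "the series" means these few. Any claim that something is new, unique, unknown or untested is made for them only; others in the source may bear on it.

For the measured compounds named here, compound 1 `CC(C)=CCc1cc(C(=O)Nc2cc3ccc(OCC4CCCNC4)c(C)c3oc2=O)ccc1O` is the only compound with a number in a functional assay on SK-BR-3 cells (Homo sapiens) for antiproliferative activity; a higher number here means a weaker inhibitor, a lower number a stronger inhibitor: compound 1 gives 600 nM. Compound 2 `CCCN(CCC)CCCOc1ccc2cc(NC(=O)c3ccc(O)c(CC=C(C)C)c3)c(=O)oc2c1C` reaches only a limit in this assay, where compound 2 gives > 50000 nM. Going by the values given here, the single measured step, an at least 83-fold higher number from compound 1 to compound 2 (1.92 log units; beyond the scatter), is known only as a limit (the limit of > 50000 nM in this assay, at which 1 of the 2 values shown sits). Compound 3 `CC(C)=CCc1cc(C(=O)Nc2cc3ccc(OCCCNC4CCCCC4)c(C)c3oc2=O)ccc1O` differs from compound 1 by 2-(cyclohexylamino)ethyl in place of piperidin-3-yl on a saturated chain carbon bound to an oxygen on an aromatic ring. This change removes the same group as the measured step, though with a different entering group, so a loss of potency beyond the scatter is expected, an 8.3-fold higher number from compound 1 to compound 3 (0.92 log units; beyond the scatter). Compound 3 is therefore estimated at 5000 nM, between 1500 nM and 30000 nM.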

Compound 3, half-maximal inhibitory concentration: 660 nM
Beside the measured number, compound 3's estimate is 7.6-fold (0.88 log units) above it; the measured number lies below the stated range.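

In this assay, piperidin-3-yl proves not to be needed on the saturated chain carbon bound to an oxygen on an aromatic ring: 2-(cyclohexylamino)ethyl in its place gives a 1.1-fold higher number from compound 1 to compound 3 (0.04 log units; within the scatter). The loss in compound 2 therefore does not follow from removing piperidin-3-yl, and cyclohexylamino in place of dipropylamino gives an at least 75-fold lower number from compound 2 to compound 3 (1.87 log units; beyond the scatter). That step rests on a limit for compound 2: the limit of > 50000 nM in this assay, at which 1 of the 3 values shown sits. Still open, on these data alone, is whether an open-chain secondary amine such as propylamino matches cyclohexylamino, or whether a cyclic tertiary amine such as piperidin-1-yl falls with dipropylamino.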